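The compounds below may be only part of what the source reports. "The series", "measured", "known", "first", "only" and "open" are said of these compounds alone.

Working notes on the series. All three measured compounds share one core, a five-membered non-aromatic ring bearing a 4-sulfamoylphenyl group and a 5-chloro-2-hydroxy-4-methylphenyl group, and differ only in the group on the saturated ring carbon. Compound 1 `Cc1cc(O)c(C2=NN(c3ccc(S(N)(=O)=O)cc3)C(c3ccccc3O)C2)cc1Cl` gives in a functional assay on NCI-H522 cells (Homo sapiens) for antiproliferative activity, with a stated time of 48 h (on this read-out higher numbers stand for lower toxicity in this test and lower numbers for higher toxicity in this test), a value of 28000 nM. Compound 2 `Cc1cc(O)c(C2=NN(c3ccc(S(N)(=O)=O)cc3)C(c3ccccc3Cl)C2)cc1Cl` gives 8330 nM in this assay, and the step between them is a 3.4-fold lower number from compound 1 to compound 2 (0.53 log units; beyond the scatter). Compound 3 `Cc1cc(O)c(C2=NN(c3ccc(S(N)(=O)=O)cc3)C(/C=C/c3ccccc3)C2)cc1Cl` gives 61800 nM in this assay and so stands at the highest number of the three; the steps leading to it are a 2.2-fold higher number from compound 1 to compound 3 (0.34 log units; beyond the scatter) and a 7.4-fold higher number from compound 2 to compound 3 (0.87 log units; beyond the scatter), both beyond the scatter.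

Compound 4 `COc1ccc(C2CC(c3cc(Cl)c(C)cc3O)=NN2c2ccc(S(N)(=O)=O)cc2)cc1OC` is not yet measured. The change from compound 3 is 3,4-dimethoxyphenyl in place of 2-phenylethenyl on a saturated ring carbon. Both measured steps at this saturated ring carbon bear on it: each time a substituted phenyl group was exchanged for 2-phenylethenyl, the number in this assay rose by a modest amount. The reverse exchange, a substituted phenyl group in place of 2-phenylethenyl, is therefore expected to lower the number by a step of similar size, with compound 4 expected to land near the two phenyl-bearing compounds, an estimated step of a 3.1-fold lower number from compound 3 to compound 4 (0.49 log units; beyond the scatter). For compound 4 the expected value in this assay is estimated at 20000 nM, within a range of 7000 nM to 60000 nM.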

Compound 4, concentration lethal to 50% of the cells: 69300 nM
Compound 4: middle estimate off by 3.5-fold (0.54 log units), on the low side; the measured number lies above the stated range.
By their numbers in this assay, from the lowest: compound 2; then compound 1; then compounds 3 and 4 (each within the scatter of the next).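

In this assay, the exchange of 2-phenylethenyl for a substituted phenyl group on the saturated ring carbon does not by itself set the number: 3,4-dimethoxyphenyl gives a 1.1-fold higher number from compound 3 to compound 4 (0.05 log units; within the scatter), and compounds 3 and 4 therefore cannot be told apart here. The phenyl-bearing compounds also differ widely among themselves, with an 8.3-fold higher number from compound 2 to compound 4 (0.92 log units; beyond the scatter) and a 2.5-fold higher number from compound 1 to compound 4 (0.39 log units; beyond the scatter), so the substituents on the phenyl ring at this position matter, and the 2-chlorophenyl of compound 2 remains alone at the low end of the four numbers. Nothing available here accounts for these differences.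

The compounds shown leave open how a plain phenyl group or a phenyl group carrying a single methoxy group would compare, and so whether the number for compound 4 comes from one methoxy group or needs both. They also leave open what happens at this carbon with a group that has no aromatic ring, such as cyclohexyl or a butyl chain, or with a group carrying an amine or a carboxylic acid.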